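The source may hold more compounds than are shown below. What is called first, only, known or untested is meant among the compounds shown, and "the series" means these compounds.

Measured in a functional assay on HeLa cells (Homo sapiens) for antiproliferative activity, with a stated time of 48 h; on this read-out higher numbers stand for weaker inhibition and lower numbers for stronger inhibition:
- Compound 1 `Cc1cc(=O)c2c(OCC3CO3)cc(OCC3CO3)cc2o1`: 5400 nM
- Compound 2 `Cc1cc(=O)c2c(OC[C@H]3CO3)cc(OC[C@H]3CO3)cc2o1`: 11400 nM
- Compound 3 `Cc1cc(=O)c2c(O)cc(OC[C@@H]3CO3)cc2o1`: 11900 nM

Compound 3 gives 11900 nM, within the scatter of compound 2 and higher than compound 1 by slightly more than the scatter. Compound 4 `Cc1cc(=O)c2c(OC[C@@H]3CO3)cc(OC[C@@H]3CO3)cc2o1` differs from compound 3 by one change: (oxiran-2-yl)methyl in place of hydrogen on an oxygen on an aromatic ring. In words, this is (oxiran-2-yl)methyl in place of hydrogen on an oxygen on an aromatic ring. Compound 4 then has the same atoms and bonds as compound 1 and compound 2, with its stereocentres drawn opposite to those of compound 2.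

Among the compounds with values here, the one measured step that bears on this is modest: a 2.1-fold higher number from compound 1 to compound 2 (0.32 log units; beyond the scatter). It goes with the fact that one of compounds 1 and 2 is drawn with a defined configuration and the other without, at the place where they differ. Compound 1, drawn without configuration, gives 5400 nM, which suggests that a configuration other than that of compound 2 could give a lower number. Against this, compound 2 already carries the added group, yet its 11400 nM stays within the scatter of compound 3. A modest move towards stronger inhibition in this assay therefore seems likely, though not certain. The expected change is a 2.6-fold lower number from compound 3 to compound 4 (0.42 log units; beyond the scatter). Compound 4 is estimated at 4500 nM, with an expected range of 1800 nM to 12000 nM.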

Compound 4, half-maximal inhibitory concentration: 21700 nM
The estimate for compound 4 lay 4.8-fold (0.68 log units) below the measured number, and the stated range ends below it.
By their numbers in this assay, from the lowest: compound 1; then compounds 2, 3 and 4 (each within the scatter of the next).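

In this assay, placing (oxiran-2-yl)methyl on the free oxygen on an aromatic ring gives no clear change, as the step stays within the scatter: a 1.8-fold higher number from compound 3 to compound 4 (0.26 log units; within the scatter). Inverting both stereocentres also gives no clear difference, so the two mirror-image forms cannot be told apart in this assay, as this step shows: a 1.9-fold higher number from compound 2 to compound 4 (0.28 log units; within the scatter). Within the data shown here, the pair that does separate involves compound 1, and a 4.0-fold higher number from compound 1 to compound 4 (0.60 log units; beyond the scatter) joins the earlier 2.1-fold higher number from compound 1 to compound 2 (0.32 log units; beyond the scatter), so neither defined configuration reproduces the lower number of compound 1, and the only difference in this pair is this: the fact that one of compounds 1 and 4 is drawn with a defined configuration and the other without, at the place where they differ.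

The compounds shown leave open whether the three-membered ring itself matters at this oxygen, which a plain propyl chain or a chain ending in an amine in place of (oxiran-2-yl)methyl would help to test. They also leave open why compound 1 gives a lower number than both of its defined forms, and the opposite configuration of compound 3 would show whether a single (oxiran-2-yl)methyl group is as insensitive to configuration as the pair of groups.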